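The source may hold more compounds than are shown below. What is called first, only, known or untested is meant among the compounds shown, and "the series" means these compounds.

Compound 1 `Cc1cccc(CSc2cc(Cl)c(C)cc2S(=O)(=O)/N=C(\N)n2nccc2-c2ccccc2)c1`: in a functional assay on MCF7 cells (Homo sapiens) for cytotoxicity, read by MTT assay, with a stated time of 72 h (on this read-out higher numbers stand for weaker inhibition and lower numbers for stronger inhibition), compound 1 gives 47000 nM.
Compound 2 `Cc1cc(S(=O)(=O)/N=C(\N)n2nccc2-c2ccccc2)c(SCc2ccccc2)cc1Cl`: in this assay compound 2 gives 20000 nM.
Compound 3 `Cc1cc(S(=O)(=O)/N=C(\N)n2nccc2-c2ccccc2)c(SCc2ccc(C(F)(F)F)cc2)cc1Cl`: in this assay compound 3 gives 25000 nM.

Compound 3 is separated from both other measured compounds by gaps within the scatter: from compound 2 by a 1.3-fold higher number from compound 2 to compound 3 (0.10 log units; within the scatter), and from compound 1 by a 1.9-fold lower number from compound 1 to compound 3 (0.27 log units; within the scatter). For the measured compounds named here, the only step beyond the scatter, a 2.4-fold lower number from compound 1 to compound 2 (0.37 log units; beyond the scatter), concerns a change on the core and not the group bound through the sulfur.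

Compound 4 `Cc1cc(S(=O)(=O)/N=C(\N)n2nccc2-c2ccccc2)c(SCc2cccc3ccccc23)cc1Cl` differs from compound 3 by naphthalen-1-yl in place of 4-(trifluoromethyl)phenyl on a saturated chain carbon bound to a sulfur. Going by the values given here, the steps that bear on this change are those that alter the aryl group on the saturated chain carbon bound to a sulfur, namely the step from compound 1 to compound 3 and the step from compound 2 to compound 3; both lay within the scatter. On that basis no step beyond the scatter is expected in this assay, in either direction. Compound 4 is therefore expected to give 22000 nM, with a range from 9000 nM to 55000 nM. This estimate corresponds to an expected step of a 1.1-fold lower number from compound 3 to compound 4 (0.06 log units; within the scatter).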

Compound 4, half-maximal inhibitory concentration: 58000 nM
For compound 4 the middle estimate is 2.6-fold (0.42 log units) below the measured one; measured number outside the range, above it.
By their numbers in this assay, from the lowest: compounds 2, 3, 1 and 4 (each within the scatter of the next, the first and the last beyond it).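

In this assay, a change at the saturated chain carbon bound to a sulfur to naphthalen-1-yl, with its two six-membered aromatic rings, gives higher numbers, and so weaker inhibition, than either 4-(trifluoromethyl)phenyl (a 2.3-fold higher number from compound 3 to compound 4 (0.37 log units; beyond the scatter)) or phenyl (a 2.9-fold higher number from compound 2 to compound 4 (0.46 log units; beyond the scatter)). The same group cannot be separated from 3-methylphenyl (a 1.2-fold higher number from compound 1 to compound 4 (0.09 log units; within the scatter)), so this second ring brought no gain over any single-ring group shown, and its penalty is seen only against two of the three. The compounds shown give no measurement that explains this result.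

They leave open whether naphthalen-2-yl would behave as naphthalen-1-yl does. They also leave open how the number would respond to cyclohexyl at this position, or to an amine or a carboxylic acid on the phenyl ring.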